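The source may hold more compounds than are shown below. What is called first, only, known or untested is meant among the compounds shown, and "the series" means these compounds.

Working notes on the series. Three compounds on the shared core have numbers in an in vitro ADME assay on microsomes from liver (Mus musculus) for pharmacokinetics, read by LC-MS, with a stated time of 10 min, tested at 1 uM; on this read-out lower numbers stand for slow clearance and higher numbers for fast clearance: compound 1 `Cc1ccc(NC(=O)[C@H]2CN(C)C[C@@H]2c2ccc(/C=C/C(=O)Nc3ccccc3N)cc2)cc1` gives 62 mL/min/kg, compound 2 `COc1ccc(NC(=O)[C@H]2CN(C)C[C@@H]2c2ccc(/C=C/C(=O)Nc3ccccc3N)cc2)cc1` gives 54 mL/min/kg, and compound 3 `CN1C[C@H](C(=O)Nc2ccc(C3CC3)cc2)[C@@H](c2ccc(/C=C/C(=O)Nc3ccccc3N)cc2)C1` gives 60 mL/min/kg. Compound 3 cannot be told apart from the other two, with a 1.0-fold lower number from compound 1 to compound 3 (0.01 log units; within the scatter) and a 1.1-fold higher number from compound 2 to compound 3 (0.05 log units; within the scatter).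

Compound 4 `CN1C[C@H](C(=O)Nc2ccc(C(F)(F)F)cc2)[C@@H](c2ccc(/C=C/C(=O)Nc3ccccc3N)cc2)C1` differs from compound 3 in one place: trifluoromethyl in place of cyclopropyl on an aromatic carbon. This puts trifluoromethyl in place of cyclopropyl on an aromatic carbon, para to a large group.

Going by the values given here, the steps that bear on this are the other group exchanges on that aromatic carbon. Besides the two above, there is a 1.1-fold lower number from compound 1 to compound 2 (0.06 log units; within the scatter). Among the compounds with values here, all three stay within the scatter, but none of the measured compounds carries trifluoromethyl, so the evidence for this group is indirect.

No step beyond the scatter is therefore expected in this assay, and no firm direction. The expected step is a 1.1-fold lower number from compound 3 to compound 4 (0.04 log units; within the scatter). Compound 4 is estimated at 55 mL/min/kg, with an expected range of 35 mL/min/kg to 80 mL/min/kg.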

Compound 4, clearance: 23 mL/min/kg
Compound 4: the middle estimate sits 2.4-fold (0.38 log units) above what was measured; measured number below the stated range.
By their numbers in this assay, from the lowest: compound 4; then compounds 2, 3 and 1 (each within the scatter of the next).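

Going by these compounds alone, on this aromatic carbon, the number in this assay does respond to the group exchange: methyl, methoxy and cyclopropyl stayed within the scatter of one another, but trifluoromethyl gives a 2.6-fold lower number from compound 3 to compound 4 (0.42 log units; beyond the scatter) and a 2.3-fold lower number from compound 2 to compound 4 (0.37 log units; beyond the scatter) and a 2.7-fold lower number from compound 1 to compound 4 (0.43 log units; beyond the scatter) as the first steps here beyond the scatter. Within the data shown here, all three steps run in the same direction and are modest, so compound 4 stands apart from compounds 1, 2 and 3, with no compound going against this within the set. Nothing measured here accounts for the lower number, which therefore stands as an observation only.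

Whether the lower number is particular to trifluoromethyl remains open, as other groups on this carbon, such as a nitrile, a chlorine or a carboxylic acid, are not among the compounds shown. Also open, on these data alone, is whether trifluoromethyl on another carbon of this aromatic ring would give a similar step.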